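A Chloro Substituent Enters a Series Without Clear Steps

The source may hold more compounds than are shown below. What is called first, only, known or untested is meant among the compounds shown, and "the series" means these compounds.

In a functional assay on A549 cells (Homo sapiens) for cytotoxicity, read by MTT assay, with a stated time of 68 h (a higher number here means a weaker inhibitor, a lower number a stronger inhibitor), three compounds built on one shared core read alike. Compound 1 `COc1ccc(-c2cccc(NC(=O)C(Cl)Cl)c2)cc1` gives 8530 nM and compound 2 `O=C(Nc1cccc(-c2ccc(F)cc2)c1)C(Cl)Cl` gives 7840 nM while compound 3 `O=C(Nc1cccc(-c2ccccc2)c1)C(Cl)Cl` gives 8900 nM on the same read-out. Compound 3 therefore stands within the scatter of both other compounds. Compound 4 `O=C(Nc1cccc(-c2ccc(Cl)cc2)c1)C(Cl)Cl` departs from compound 3 in one place, with chloro in place of hydrogen on an aromatic carbon as the whole change, so that chloro sits on an aromatic carbon para to a large group. For the measured compounds named here, no chloro compound has been measured yet, so the nearest evidence comes from substituents at that same place. Replacing fluoro with hydrogen gave a 1.1-fold higher number from compound 2 to compound 3 (0.06 log units; within the scatter) and replacing methoxy with hydrogen gave a 1.0-fold higher number from compound 1 to compound 3 (0.02 log units; within the scatter) and neither step leaves the scatter. No step beyond the scatter is therefore expected in this assay for the new substituent. The estimate means a 1.1-fold lower number from compound 3 to compound 4 (0.06 log units; within the scatter) as the expected step. Compound 4 is expected at 7800 nM (4500 nM to 12500 nM).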

Compound 4, half-maximal inhibitory concentration: 36200 nM
Compound 4: middle estimate off by 4.6-fold (0.67 log units), on the low side, outside the stated range (above it).
By their numbers in this assay, from the lowest: compounds 2, 1 and 3 (each within the scatter of the next); then compound 4.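

This position is not indifferent to what sits on it: chloro in place of hydrogen gives a 4.1-fold higher number from compound 3 to compound 4 (0.61 log units; beyond the scatter) in this assay and so leaves the scatter that had held fluoro, methoxy and hydrogen together. The same holds for chloro in place of fluoro, with a 4.6-fold higher number from compound 2 to compound 4 (0.66 log units; beyond the scatter) as the step, and for chloro in place of methoxy, with a 4.2-fold higher number from compound 1 to compound 4 (0.63 log units; beyond the scatter) as the step, so among the four groups shown on this aromatic carbon only chloro sets its compound apart, as the weakest of the four. No measurement offered here accounts for this separation of chloro from the other three groups.

As far as these compounds go, whether bromo or trifluoromethyl at this place would read with compound 4 or with the other three compounds stays open. From the compounds shown here alone, an amine or a carboxylic acid at this place is equally open.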